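Furan to Thiophene Swaps on a Shared Core

The compounds below may be only part of what the source reports. "The series", "measured", "known", "first", "only" and "open" are said of these compounds alone.

Measured in a functional assay on HCT-116 cells (Homo sapiens) for inhibition, read by sulforhodamine B assay, with a stated time of 2 days; on this read-out lower numbers stand for stronger inhibition of growth and higher numbers for weaker inhibition of growth:
- compound 1, `CC1=C(C(=O)Nc2cccc([N+](=O)[O-])c2)C(c2ccc(O)cc2O)NC(N/N=C/c2ccco2)=N1`, gives 8890 nM
- compound 2, `CC1=C(C(=O)Nc2cccc([N+](=O)[O-])c2)C(c2ccc(O)cc2O)NC(N/N=C/c2cccs2)=N1`, gives 38200 nM
- compound 3, `CC1=C(C(=O)Nc2cccc([N+](=O)[O-])c2)C(c2ccc(O)cc2O)NC(NN2C(=O)/C(=C\c3ccco3)SC2=S)=N1`, gives > 100000 nM, which is a limit of the assay and not a number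

Compound 1 and compound 2 share one core and differ only by thiophen-2-yl in place of furan-2-yl on a carbon with a double bond to nitrogen. The step of a 4.3-fold higher number from compound 1 to compound 2 (0.63 log units; beyond the scatter) shows that this exchange weakened growth inhibition in this assay. Compound 3 carries a different, larger attachment on the same core; the difference between the two cores is not broken down here. Compound 3 sits at the limit of > 100000 nM in this assay, at which 1 of the 3 values shown sits, so only a limit is known for it.

Compound 4, `CC1=C(C(=O)Nc2cccc([N+](=O)[O-])c2)C(c2ccc(O)cc2O)NC(NN2C(=O)/C(=C\c3cccs3)SC2=S)=N1`, is not yet measured. It differs from compound 3 by thiophen-2-yl in place of furan-2-yl on a double-bonded chain carbon bound to a double-bonded ring carbon. Going by the values given here, this is the same kind of change as the one from compound 1 to compound 2, not the same change: there the place is on a carbon with a double bond to nitrogen whose other neighbours are: double-bonded nitrogen, here it is on a double-bonded chain carbon bound to a double-bonded ring carbon.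

Among the compounds with values here, the expected step that the limit leaves unreadable from compound 3 to compound 4 rests on two things: compound 3 already reaches only a limit with > 100000 nM, and the one measured example of this kind of change, a 4.3-fold higher number from compound 1 to compound 2 (0.63 log units; beyond the scatter), raised the number. Compound 4 is therefore expected to give 250000 nM in this assay, most likely again reported only as a limit, with an estimated range from 100000 nM to 1000000 nM.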

Compound 4, concentration for 50% growth inhibition: 4500 nM
Compound 4: the middle estimate sits 56-fold (1.74 log units) above what was measured; the whole stated range lies above it.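

In this assay, thiophen-2-yl in place of furan-2-yl on a double-bonded chain carbon bound to a double-bonded ring carbon gave an at least 22-fold lower number from compound 3 to compound 4 (1.34 log units; beyond the scatter), which means stronger growth inhibition, so the exchange that weakened growth inhibition with the smaller attachment of compound 1 did the opposite here, and the direction of the step did not carry over: the same change on two cores in this assay, a 4.3-fold higher number (0.63 log units; beyond the scatter) from compound 1 to compound 2 and an at least 22-fold lower number (1.34 log units; beyond the scatter) from compound 3 to compound 4, at least 95-fold (1.97 log units) apart, beyond the scatter of two such steps. Compound 3 is known only as a limit, so this step has a minimum size and no exact one: the limit of > 100000 nM in this assay, at which 1 of the 4 values shown sits. Going by these compounds alone, this shows that the result of the exchange on one core cannot simply be transferred to another, but with only two pairs it does not show which part of the structure reverses the direction, and it gives no rule for any further core.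

The compounds shown leave open which part of the larger attachment shared by compound 3 and compound 4 goes with the reversal. They also leave open how a phenyl group, or a furan-2-yl or thiophen-2-yl ring carrying a methyl group or a carboxylic acid, would read in the same place on either core.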